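The source may report more compounds than this note shows. Statements on the series, on what has been measured and on what is new or still open speak of the compounds shown alone.

Measured so far:
Compound 1 `Nc1ncnc2c1c(-c1cnc3[nH]ccc3c1)nn2CCCC(=O)NO`: only an assay limit, > 150000 nM in a functional assay on MCF7 cells (Homo sapiens) for inhibition, read by MTT assay, with a stated time of 72 h; a lower number here means a stronger inhibitor, a higher number a weaker inhibitor.
Compound 2 `Nc1nc2cc(-c3nn(CCCCCCCCCC(=O)NO)c4ncnc(N)c34)ccc2o1`: only an assay limit, > 50000 nM in this assay.
Compound 3 `Nc1ncnc2c1c(-c1cnc3[nH]ccc3c1)nn2CCCCCCC(=O)NO`: 19800 nM in this assay.

Within the data shown here, compound 3 thus carries the only real number of the three. Compound 1 sits at a limit (the limit of > 150000 nM in this assay, at which 1 of the 3 values shown sits). Compound 2 sits at a limit (the limit of > 50000 nM in this assay, at which 1 of the 3 values shown sits).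

Compound 4 `Nc1ncnc2c1c(-c1cnc3[nH]ccc3c1)nn2CCCCCC(=O)NO` has not yet been measured. It differs from compound 3 by hydroxycarbamoyl in place of (hydroxycarbamoyl)methyl on a saturated chain carbon, five bonds along the chain from an aromatic nitrogen. Among the measured compounds shown here, the one measured step that bears on this change, an at least 7.5-fold lower number from compound 1 to compound 3 (0.87 log units; beyond the scatter), went the other way: a longer chain gave a lower number. Compound 4 shortens the chain by one link, so the step of a 1.5-fold higher number from compound 3 to compound 4 (0.18 log units; within the scatter) is expected to be a somewhat higher number, close to the scatter. Compound 4 is therefore estimated at 30000 nM, in a range from 10000 nM to 90000 nM.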

Compound 4, half-maximal inhibitory concentration: > 150000 nM
Compound 4: no number, only a limit (the forecaster's own chance of this, stated with the estimate: 25%); middle value at least 5.0-fold (0.69 log units) away from the limit.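

Taking a single link off the chain gives an at least 7.5-fold higher number from compound 3 to compound 4 (0.87 log units; beyond the scatter) and so shows that, at this position, one link alone can move the result beyond the scatter. Compound 4 gives only a limit, the same one as compound 1, and the step between those two cannot be read: the limit of > 150000 nM in this assay, at which 2 of the 4 values shown sit. Among these compounds on this core, only the 3-(hydroxycarbamoyl)propyl-extended chain of compound 3 gives a real number. As far as these compounds go, whether a longer chain on the core of compound 3 would lower the number further stays open, as does whether a carboxylic acid or an amine could replace the hydroxycarbamoyl end.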